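Aryl variation on the imidazopyrazine series: acetylphenyl analogue

The source may hold more compounds than are shown below. What is called first, only, known or untested is meant among the compounds shown, and "the series" means these compounds.

Measured so far:
compound 1 `c1ccc2c(-c3cn4ccnc4c(-c4ccc5ncn(C6CCCCC6)c5c4)n3)cccc2c1`: 7.43%
compound 2 `c1cn2cc(-c3ccsc3)nc(-c3ccc4ncn(C5CCCCC5)c4c3)c2n1`: 4.9%

In a functional assay on LOX IMVI cells (Homo sapiens) for inhibition, read by sulforhodamine B assay, with a stated time of 48 h, tested at 10 uM (a higher number here means more inhibition at the concentration tested (going by the name of the read-out), a lower number less inhibition), compound 1 gives 7.43% and compound 2 gives 4.9%. Among the compounds with values here, the one step available, a number 2.5 percentage points lower from compound 1 to compound 2 (within the scatter), means compound 2 and compound 1 cannot be told apart on these numbers; compound 2 holds the lower of the two figures only nominally.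

Compound 3 `CC(=O)c1ccc(-c2cn3ccnc3c(-c3ccc4ncn(C5CCCCC5)c4c3)n2)cc1` is the next member. The change from compound 2 is 4-acetylphenyl in place of thiophen-3-yl on an aromatic carbon. Within the data shown here, no measured step involves 4-acetylphenyl, so only the step of a number 2.5 percentage points lower from compound 1 to compound 2 (within the scatter) can be drawn on, and it shows that exchanging the aryl group at this position left the read-out within scatter. On that basis no step beyond the scatter is expected from compound 2 to compound 3, i.e. a number 1.1 percentage points higher from compound 2 to compound 3 (within the scatter). The estimate for compound 3 in this assay is therefore 6%, with a range of -8% to 20%.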

Compound 3, a percentage reported as inhibition, at one concentration (the size of the read-out at that concentration, not a potency): 14.5%
Compound 3: the middle estimate sits 8.5 percentage points below what was measured; low and high end bracket the measured number.
By their numbers in this assay, from the lowest: compounds 2, 1 and 3 (each within the scatter of the next).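

With 4-acetylphenyl at this position, this assay gives a number 9.6 percentage points higher from compound 2 to compound 3 (within the scatter) and a number 7.1 percentage points higher from compound 1 to compound 3 (within the scatter). Within the data shown here, the earlier compounds carried only the unsubstituted naphthalen-1-yl and thiophen-3-yl groups, so this is the first aryl group here with a substituent, a carbonyl-bearing acetyl, and the read-out still stays within the scatter of both. The three compounds therefore cannot be ranked in this assay, and nothing available bears on the reason for these read-outs.

Still open, from the compounds shown here alone, is whether an amine or a carboxylic acid in place of the acetyl group on the phenyl ring would give a step beyond the scatter. Also open, going by these compounds, is whether any aryl group at this position would do so with a group other than cyclohexyl on the shared core.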